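Swapping a fluorophenyl for a quinolinyl on an amidine

The source may hold more compounds than are shown below. What is called first, only, known or untested is meant among the compounds shown, and "the series" means these compounds.

Measured so far:
compound 1 `CC(C)CCc1sc(NC(=O)c2cc(NC(=O)c3cc(NC(=N)c4cccc(F)c4)cn3C)cn2C)nc1C(=O)NCCCN(C)C`: 18 ug/mL
compound 2 `COc1cccc(C(=N)Nc2cc(C(=O)Nc3cc(C(=O)Nc4cc(C(=O)NCCCN(C)C)n(C)c4)n(C)c3)n(C)c2)c1`: "not determined" (no result reported)

Among the measured compounds shown here, in an ADME assay on HEK293 cells (Homo sapiens) for cytotoxicity, read by fluorescence and resazurin assay, with a stated time of 20 h (on this read-out lower numbers stand for higher toxicity in this test and higher numbers for lower toxicity in this test), compound 1 gives 18 ug/mL, the only number available. Compound 2 gives "not determined" (no result reported). Compound 3 `CC(C)CCc1sc(NC(=O)c2cc(NC(=O)c3cc(NC(=N)c4cnc5ccccc5c4)cn3C)cn2C)nc1C(=O)NCCCN(C)C` carries quinolin-3-yl in place of 3-fluorophenyl on a carbon with a double bond to nitrogen. For the measured compounds named here, no measured pair shows what such a change does here, so the step from compound 1 to compound 3 cannot be anchored; a modest move toward greater toxicity is expected, a 1.5-fold lower number from compound 1 to compound 3 (0.18 log units; within the scatter), barely beyond the scatter. Compound 3 is expected to give 12 ug/mL, within 5 ug/mL to 35 ug/mL.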

Compound 3, half-maximal cytotoxic concentration: 1.2 ug/mL
Compound 3: the middle estimate sits 10-fold (1.00 log units) above what was measured; measured number outside the range, below it.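

On the carbon with a double bond to nitrogen, the group carried there clearly matters in this assay: quinolin-3-yl in place of 3-fluorophenyl gives a 15-fold lower number from compound 1 to compound 3 (1.18 log units; beyond the scatter) and moves the series toward higher toxicity. A single swap on the shared core is therefore enough to change this read-out by a large margin, well beyond the usual scatter. Nothing available here explains the shift. Still open, on these data alone, is whether the ring nitrogen or the second ring is responsible, which a naphthalen-2-yl group, made of carbon only, could separate. Compound 2 has no reported result, so it adds no comparison.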